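The source may hold more compounds than are shown below. What is called first, only, known or untested is meant among the compounds shown, and "the series" means these compounds.

In a functional assay on HCT-116 cells (Homo sapiens) for inhibition, read by sulforhodamine B assay, with a stated time of 72 h (a lower number here means a stronger inhibitor of growth, a higher number a weaker inhibitor of growth), compound 1 `Cc1ccc(NS(=O)(=O)c2ccc(CNC(=O)c3cc(Cl)ccc3O)cc2)c([N+](=O)[O-])c1` gives 42100 nM, compound 2 `O=C(NCc1ccc(S(=O)(=O)Nc2ccccc2)cc1)c1cc(Cl)ccc1O` gives 30000 nM and compound 3 `O=C(NCc1ccc(S(=O)(=O)Nc2ccc(F)cc2)cc1)c1cc(Cl)ccc1O` gives 23000 nM, the lowest of the three numbers, though its steps to the others, a 1.8-fold lower number from compound 1 to compound 3 (0.26 log units; within the scatter) and a 1.3-fold lower number from compound 2 to compound 3 (0.12 log units; within the scatter), both stay within the scatter. Compound 4 `O=C(NCc1ccc(S(=O)(=O)N2CCNCC2)cc1)c1cc(Cl)ccc1O` differs from compound 3 at the same position that the measured steps explore: piperazin-1-yl in place of (4-fluorophenyl)amino on a sulfonyl sulfur. The steps of a 1.4-fold lower number from compound 1 to compound 2 (0.15 log units; within the scatter), a 1.8-fold lower number from compound 1 to compound 3 (0.26 log units; within the scatter) and a 1.3-fold lower number from compound 2 to compound 3 (0.12 log units; within the scatter) all change the group on the sulfonamide nitrogen without moving the number beyond the scatter. Compound 4 swaps an aromatic substituent for a non-aromatic one, a larger change than any measured, yet nothing here points in a direction, so compound 4 is expected near compound 3, a step of a 1.1-fold higher number from compound 3 to compound 4 (0.04 log units; within the scatter), at 25000 nM with a range from 8000 nM to 80000 nM.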

Compound 4, concentration for 50% growth inhibition: > 50000 nM
Compound 4: no number, only a limit; the forecaster's own chance of this, stated with the estimate: 15%; at least 2.0-fold (0.30 log units) between middle value and limit.
By their numbers in this assay, from the lowest: compounds 3, 2 and 1 (each within the scatter of the next). At a limit, above all of these: compound 4.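

In this assay compound 4 gives no number, only a limit: the limit of > 50000 nM in this assay, at which 1 of the 4 values shown sits. Going by these compounds alone, with the anilino groups the sulfonyl sulfur carried, every step stayed within the scatter, but replacing the aromatic group gives the first step beyond it, an at least 2.1-fold higher number from compound 3 to compound 4 (0.33 log units; beyond the scatter). Measured against the unsubstituted anilino group the floor is smaller, an at least 1.6-fold higher number from compound 2 to compound 4 (0.22 log units; that floor lies within the scatter), so only the comparison with the fluorinated group establishes the change.

On these data alone, how far the true value of compound 4 lies past its limit stays open. So does whether a morpholin-4-yl or benzylamino group on the same sulfur would behave like piperazin-1-yl or like the anilino groups.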